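The source may report more compounds than this note shows. Statements on the series, on what has been measured and on what is new or still open speak of the compounds shown alone.

Among the measured compounds shown here, compound 2 `CN(C)c1ccc(C(=O)Nc2cc(Br)cc(NC(=O)COc3ccc4c(=O)ccoc4c3)c2)cc1` is one of two compounds measured in an assay on isolated protein for inhibition of Rho-associated protein kinase 1 (Homo sapiens), read by scintillation counting, radiometric assay and 33P incorporation, with a stated time of 40 min, in the presence of a further agent that is not named here; on this read-out lower numbers stand for stronger inhibition and higher numbers for weaker inhibition. Its result is a limit of the assay: in this assay compound 2 gives > 10000 nM. Compound 1 `Cc1cc(NC(=O)COc2ccc3c(=O)ccoc3c2)cc(NC(=O)c2ccc(N(C)C)cc2)c1` differs from it by bromo in place of methyl on an aromatic carbon, and its result is also a limit: in this assay compound 1 gives > 10000 nM. For the measured compounds named here, the step from compound 1 to compound 2 is therefore unreadable, a step that the two limits leave unreadable from compound 1 to compound 2, and the only evidence at hand is the limit of > 10000 nM in this assay, at which 2 of the 2 values shown sit.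

Compound 3 `CN(C)c1ccc(C(=O)Nc2cc(NC(=O)COc3ccc4c(=O)ccoc4c3)cc(C(F)(F)F)c2)cc1` carries a further change: trifluoromethyl in place of bromo on an aromatic carbon, meta to two large groups. Going by the values given here, no measured step shows how large a change of this kind can be, because of the limit of > 10000 nM in this assay, at which 2 of the 2 values shown sit. The expectation is therefore that compound 3 stays where compound 2 stands, and a step that the limit leaves unreadable from compound 2 to compound 3 in this assay is expected. Compound 3 is estimated at 15000 nM, within 4000 nM to 60000 nM, and is most likely to be reported again only as a limit.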

Compound 3, half-maximal inhibitory concentration: > 10000 nM
Compound 3 was reported as a limit; the forecaster's own chance of this, stated with the estimate: 85%; the middle value lies beyond the limit too.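

Compound 3, like compound 1 and compound 2, is reported in this assay only as a limit, so neither step leading to compound 3 can be read: the limit of > 10000 nM in this assay, at which 3 of the 3 values shown sit. The compounds shown leave open how strongly any of them inhibits the kinase, and whether methyl, bromo or trifluoromethyl at this place makes any difference.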